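From cyano to nitro at the assay limit

The source may hold more compounds than are shown below. What is called first, only, known or untested is meant among the compounds shown, and "the series" means these compounds.

- Compound 1 `O=C(Nc1ccc(Br)cc1)N1CCC[C@H]1c1nc(-c2ccccc2)no1` reads > 50000 nM as a limit
- Compound 2 `N#Cc1ccc(NC(=O)N2CCC[C@H]2c2nc(-c3ccccc3)no2)cc1` reads > 50000 nM as a limit

In an ADME assay on MCF-10A cells (Homo sapiens) for inhibition, with a stated time of 48 h (on this read-out higher numbers stand for weaker inhibition and lower numbers for stronger inhibition), compound 2 stands at > 50000 nM and this is a limit, not a number. Compound 3 `O=C(Nc1ccc([N+](=O)[O-])cc1)N1CCC[C@H]1c1nc(-c2ccccc2)no1` has nitro in place of cyano on an aromatic carbon, para to a large group (nitro in place of cyano on an aromatic carbon). Among the measured compounds shown here, the only measured step is a step that the two limits leave unreadable from compound 1 to compound 2 and it offers no size to carry over. The evidence so far is the limit of > 50000 nM in this assay, at which 2 of the 2 values shown sit, and nothing more. No step beyond the scatter is therefore expected in this assay for this change. The estimated step is a step that the limit leaves unreadable from compound 2 to compound 3 for now. Compound 3 is expected at 60000 nM within an estimated range from 25000 nM to 150000 nM and may well report only a limit.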

Compound 3, half-maximal inhibitory concentration: > 50000 nM
Compound 3: only a limit was reported (the forecaster's own chance of this, stated with the estimate: 80%); the middle value lies beyond the limit too.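

Among the compounds shown here, compound 3, like compound 1 and compound 2, gives only a limit in this assay, so no step among them can be read. The compounds shown leave open whether bromo, cyano and nitro differ at all in this assay.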